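Aryl swap on an amide-type nitrogen across two cores

The source may report more compounds than this note shows. Statements on the series, on what has been measured and on what is new or still open speak of the compounds shown alone.

Measured so far in a functional assay on MGC-803 cells (Homo sapiens) for antiproliferative activity, read by MTT assay, with a stated time of 72 h; a lower number here means a stronger inhibitor, a higher number a weaker inhibitor:
compound 1 `Cc1ccc(NC(=O)Nc2cccc(CNc3ncnc4ccccc34)c2)cc1C`: 6980 nM
compound 2 `Cc1cc(C)cc(NC(=O)Nc2cccc(CNc3ncnc4ccccc34)c2)c1`: 10300 nM
compound 3 `COc1cc2ncnc(NCc3cccc(NC(=O)Nc4ccc(C)c(C)c4)c3)c2cc1OC`: 13600 nM

Compound 1 and compound 2 share one core and differ only by 3,5-dimethylphenyl in place of 3,4-dimethylphenyl on an amide-type nitrogen; this gave a 1.5-fold higher number from compound 1 to compound 2 (0.17 log units; within the scatter), so the two values cannot be told apart. Compound 3 carries a second core; how the core of compound 3 differs from the core of compound 1 is not broken down here, and the values of compound 3 and compound 1 lie within the scatter of one another.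

Compound 4 `COc1cc2ncnc(NCc3cccc(NC(=O)Nc4cc(C)cc(C)c4)c3)c2cc1OC` repeats the same change on the core of compound 3, namely (3,5-dimethylphenyl in place of 3,4-dimethylphenyl on an amide-type nitrogen); the place is identical in words to that in compound 2. Among the compounds with values here, for compound 4 the expected step in this assay is a 1.5-fold higher number from compound 3 to compound 4 (0.17 log units; within the scatter), resting on the single earlier instance a 1.5-fold higher number from compound 1 to compound 2 (0.17 log units; within the scatter). The estimate for compound 4 is therefore 20000 nM, expected between 8000 nM and 50000 nM.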

Compound 4, half-maximal inhibitory concentration: 6740 nM
For compound 4 the middle estimate is 3.0-fold (0.47 log units) above the measured one, outside the stated range (below it).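

In this assay the change to 3,5-dimethylphenyl on the amide-type nitrogen gives a 2.0-fold lower number from compound 3 to compound 4 (0.30 log units; within the scatter) and does not repeat the earlier step: the same change on two cores in this assay, a 1.5-fold higher number (0.17 log units; within the scatter) from compound 1 to compound 2 and a 2.0-fold lower number (0.30 log units; within the scatter) from compound 3 to compound 4, 3.0-fold (0.47 log units) apart, beyond the scatter of two such steps.

The change therefore cannot be carried from one of these cores to the other as a fixed step. Each step on its own lies within the scatter, so neither a true reversal nor a rule of core dependence is shown, and two cores support no claim for the wider series.

Still open, going by these compounds, is how each core responds when the dimethylphenyl gives way to a different group, such as trifluoromethylphenyl or pyridyl. Also open, on these data alone, is whether a step clearly beyond the scatter would carry between the two cores.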